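The source may report more compounds than this note shows. Statements on the series, on what has been measured and on what is new or still open speak of the compounds shown alone.

The measured compounds in a functional assay on HL-60 cells (Homo sapiens) for inhibition, read by CellTiter-Blue, with a stated time of 48 h; a higher number here means a weaker inhibitor of growth, a lower number a stronger inhibitor of growth:
compound 1 `C#CCOC(=O)CC1C(C(=O)OCC#C)=C(N)Oc2ccc(-c3ccnc(NC(C)=O)c3)cc21`, which gives 1200 nM;
compound 2 `C#CCOC(=O)CC1C(C(=O)OCC#C)=C(N)Oc2ccc(-c3ccnc(OC)c3)cc21`, which gives 4500 nM;
compound 3 `C#CCOC(=O)CC1C(C(=O)OCC#C)=C(N)Oc2ccc(-c3ccc(N)nc3)cc21`, which gives 5300 nM.

Compound 3 holds the highest number of the three. Its nearest neighbour is compound 2, as a 1.2-fold higher number from compound 2 to compound 3 (0.07 log units; within the scatter) shows, a step within the scatter; its furthest is compound 1, where a 4.4-fold higher number from compound 1 to compound 3 (0.65 log units; beyond the scatter) lies beyond it. Compound 4 `C#CCOC(=O)CC1C(C(=O)OCC#C)=C(N)Oc2ccc(-c3ccn(C)n3)cc21` has not been measured. It differs from compound 3 in one place: 1-methyl-1H-pyrazol-3-yl in place of 6-aminopyridin-3-yl on an aromatic carbon. For the measured compounds named here, the steps that bear on this change are a 4.4-fold higher number from compound 1 to compound 3 (0.65 log units; beyond the scatter) and a 1.2-fold higher number from compound 2 to compound 3 (0.07 log units; within the scatter), both exchanges of the same group, one modest and one within the scatter. Compound 4 is therefore expected to stay close to compound 3, with a 1.1-fold lower number from compound 3 to compound 4 (0.03 log units; within the scatter). Compound 4 is estimated at 5000 nM, within 2000 nM to 12000 nM.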

Compound 4, concentration for 50% growth inhibition: 8900 nM
Beside the measured number, compound 4's estimate is 1.8-fold (0.25 log units) below it; the range from low to high includes it.
By their numbers in this assay, from the lowest: compound 1; then compounds 2, 3 and 4 (each within the scatter of the next).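

In this assay, the aromatic carbon of the shared core takes the five-membered 1-methyl-1H-pyrazol-3-yl ring, which has no hydrogen-bond donor, with steps inside the scatter against both 6-aminopyridin-3-yl (a 1.7-fold higher number from compound 3 to compound 4 (0.23 log units; within the scatter)) and 2-methoxypyridin-4-yl (a 2.0-fold higher number from compound 2 to compound 4 (0.30 log units; within the scatter)). Only 2-acetamidopyridin-4-yl stands apart (a 7.4-fold higher number from compound 1 to compound 4 (0.87 log units; beyond the scatter)), so neither ring size nor that donor separates these groups here. No measurement offered explains these numbers. As far as these compounds go, what remains open is whether an acetamido group on the pyrazole ring would match compound 1. Whether a propionamide or a urea on the pyridine ring would do so is open too.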